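This account rests on a few compounds, and the source may have more. Where it says the series, first, only, none or still open, it means among the compounds named here.

Compound 1 `Nc1cc(N)c2nc(-c3ccccc3)c(Oc3ccc(Cl)c(Cl)c3)nc2c1` — 38000 nM
Compound 3 `Nc1cc(N)c2nc(-c3ccccc3)c(NCc3ccc(Cl)c(Cl)c3)nc2c1` — 31600 nM
Compound 2 `CCOC(=O)[C@H](CCC(=O)O)NC(=O)c1ccc(CNc2nc3cc(N)cc(N)c3nc2-c2ccccc2)cc1` — < 100000 nM, a limit of the assay

In a functional assay on HOP-62 cells (Homo sapiens) for inhibition, read by sulforhodamine B assay, with a stated time of 48 h (a higher number here means a weaker inhibitor of growth, a lower number a stronger inhibitor of growth), compound 1 gives 38000 nM. Compound 3 gives 31600 nM, and the two numbers lie within the scatter of each other, so compound 1 and compound 3 sit together on the numbers shown. For compound 2 the assay reports only a limit, < 100000 nM, and no number. Among the three compounds, then, only two numbers exist, and they do not separate.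

Compound 4 `Nc1cc(N)c2nc(-c3ccccc3)c(Sc3ccc(Cl)c(Cl)c3)nc2c1` has not yet been measured. It differs from compound 1 by (3,4-dichlorophenyl)sulfanyl in place of 3,4-dichlorophenoxy on an aromatic carbon. Among the compounds with values here, no measured pair shows a change at this place, so there is no measured step to draw on; what the numbers show is that compound 1 and compound 3, which carry different links at this place, give values that lie within the scatter of each other. On that basis the expected step is a 1.2-fold lower number from compound 1 to compound 4 (0.07 log units; within the scatter), within the scatter. Compound 4 is therefore expected to give 32000 nM, estimated between 10000 nM and 95000 nM.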

Compound 4, concentration for total growth inhibition: 77600 nM
Estimate against measurement, compound 4: 2.4-fold (0.38 log units) below, within the range that was stated.
By their numbers in this assay, from the lowest: compounds 3 and 1 (each within the scatter of the next); then compound 4.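

In this assay, 3,4-dichlorophenoxy gives way to (3,4-dichlorophenyl)sulfanyl on the aromatic carbon next to the ring nitrogen, with a 2.0-fold higher number from compound 1 to compound 4 (0.31 log units; beyond the scatter). Within the data shown here, this is the first measured step at this place, and it shows that the link at this position can change the number, although the step is modest. Compound 1 and compound 3 had not separated, so the earlier values gave no sign that exchanging oxygen for sulfur, with the heavy-atom count unchanged, would weaken growth inhibition.

Whether a sulfonyl link, or an amine or a carboxylic acid on the outer aromatic ring, would move the number further stays open, and this single step names no cause. Compound 2 carries only a limit, which gives no number for comparison: the limit of < 100000 nM in this assay, at which 1 of the 4 values shown sits.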